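A few compounds are considered here, and "the series" means these few. Any claim that something is new, unique, unknown or untested is made for them only; others in the source may bear on it.

Measured in an ADME assay on MRC5 cells (Homo sapiens) for antiproliferative activity, read by fluorescence and resazurin assay, with a stated time of 68 h; a higher number here means that more compound is needed for the effect, a lower number that less compound is needed:
- compound 1 `Cc1ccc(-c2cc(C(=O)Nc3cccnc3)c3cc(F)ccc3n2)cc1`: 50000 nM
- compound 2 `Cc1ccc(-c2cc(C(=O)NCCN(C)C)c3cc(Cl)ccc3n2)cc1`: 9000 nM
- compound 3 `Cc1cc(Nc2cc(C(=O)NCCN3CCCC3)c3cc(F)ccc3n2)on1`: > 50000 nM (a limit)

Compound 3 stands at > 50000 nM, which is a limit and not a number. Compound 4 `O=C(NCCN1CCCC1)c1cc(NCCN2CCCCC2)nc2ccc(F)cc12` has 2-(piperidin-1-yl)ethyl in place of 3-methyl-1,2-oxazol-5-yl on a nitrogen on an aromatic ring. Among the measured compounds shown here, no measured pair isolates this change, so its size in this assay remains uncertain. The expectation of a move toward less compound needed rests on compound 2, which at 9000 nM shows that a compound of this small set can give a measured number. The expected change is an at least 3.3-fold lower number from compound 3 to compound 4 (0.52 log units; beyond the scatter). For compound 4 the estimate is 15000 nM, with an expected range from 4000 nM to 50000 nM.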

Compound 4, half-maximal effective concentration: 19000 nM
Estimate against measurement, compound 4: 1.3-fold (0.10 log units) below; the measured number falls inside the stated range.
By their numbers in this assay, from the lowest: compound 2; then compound 4; then compound 1.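

In this assay the exchange of 3-methyl-1,2-oxazol-5-yl for 2-(piperidin-1-yl)ethyl on this nitrogen brings an at least 2.6-fold lower number from compound 3 to compound 4 (0.42 log units; beyond the scatter) and gives the first step read at this place. It shows that the group on this nitrogen can move the number beyond the scatter. Compound 3 carries a limit, so the step is only a lower bound, because its starting point is not a number: the limit of > 50000 nM in this assay, at which 1 of the 4 values shown sits.

On these data alone, it remains open whether the basic nitrogen of the piperidine matters, or whether a morpholine ring or a plain butyl chain on this nitrogen would give a similar number. As far as these compounds go, the true size of this step also remains open.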